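The source may report more compounds than this note shows. Statements on the series, on what has been measured and on what is new or still open speak of the compounds shown alone.

Compound 1 `COc1cccc(/C=C/C(=O)C(=Cc2ccc(F)cc2)C(=O)/C=C/c2cccc(OC)c2OC)c1OC` is the reference point of this set. In a functional assay on CNE-2 cells (Homo sapiens) for antiproliferative activity, read by sulforhodamine B assay, with a stated time of 48 h (a lower number here means a stronger inhibitor, a higher number a weaker inhibitor), compound 1 gives 610 nM, the highest of the three numbers recorded. Compound 2 `COc1cc(C=C(C(=O)/C=C/c2cccc(OC)c2OC)C(=O)/C=C/c2cccc(OC)c2OC)ccc1O` gives 280 nM in this assay, and compound 3 `COc1ccc(C=C(C(=O)/C=C/c2cccc(OC)c2OC)C(=O)/C=C/c2cccc(OC)c2OC)cc1OC` gives 280 nM. Both changes to the aryl group on the chain carbon have helped: a 2.2-fold lower number from compound 1 to compound 2 (0.34 log units; beyond the scatter) and a 2.2-fold lower number from compound 1 to compound 3 (0.34 log units; beyond the scatter), while no change at the digits printed from compound 2 to compound 3 (within the scatter). Compound 4 `COc1cccc(/C=C/C(=O)C(=Cc2ccc(OC)c(OC)c2OC)C(=O)/C=C/c2cccc(OC)c2OC)c1OC` makes a related change: 2,3,4-trimethoxyphenyl in place of 4-fluorophenyl on a double-bonded chain carbon bound to a double-bonded chain carbon. Since each replacement of the 4-fluorophenyl by a methoxy-bearing aryl has lowered the number by a modest but real amount, a similar modest drop is expected here, so compound 4 is estimated to give 300 nM in this assay, within 150 nM to 600 nM, which means an expected step of a 2.0-fold lower number from compound 1 to compound 4 (0.31 log units; beyond the scatter).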

Compound 4, half-maximal inhibitory concentration: 410 nM
Compound 4: the middle estimate sits 1.4-fold (0.14 log units) below what was measured, and the stated range covers the measured number.
By their numbers in this assay, from the lowest: compounds 2, 3, 4 and 1 (each within the scatter of the next, the first and the last beyond it).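

In this assay, 2,3,4-trimethoxyphenyl on the double-bonded chain carbon does not separate from 4-fluorophenyl (a 1.5-fold lower number from compound 1 to compound 4 (0.17 log units; within the scatter)), unlike 3,4-dimethoxyphenyl and 4-hydroxy-3-methoxyphenyl. Within the data shown here, it also stays within the scatter of those two groups (a 1.5-fold higher number from compound 3 to compound 4 (0.17 log units; within the scatter); a 1.5-fold higher number from compound 2 to compound 4 (0.17 log units; within the scatter)), so the added methoxy gives no step that can be read as a real change. No measurement given here explains this result. From the compounds shown here alone, whether an amine or a carboxylic acid on this aryl group would move the number beyond the scatter remains open.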